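Methoxy to Ethoxy: Estimating Compound 4

The source may hold more compounds than are shown below. What is called first, only, known or untested is meant among the compounds shown, and "the series" means these compounds.

Three compounds have been measured in an assay on isolated protein (strain Sprague-Dawley) for inhibition of Amine oxidase [flavin-containing] B (Rattus norvegicus), read by spectrophotometry, with a stated time of 5 min; a higher number here means a weaker inhibitor, a lower number a stronger inhibitor:
compound 1 `CCOc1cc(=O)oc2cc(OCc3cccc(F)c3)ccc12` gives 263 nM
compound 2 `CCOc1cc(=O)oc2cc(OCc3cccc(Cl)c3)ccc12` gives 115 nM
compound 3 `COc1cc(=O)oc2cc(OCc3cccc(Br)c3)ccc12` gives 5.75 nM

Compound 3 gives the lowest number of the three, and its steps to the other two lie beyond the scatter, so it is the strongest inhibitor of this set. Compound 4 `CCOc1cc(=O)oc2cc(OCc3cccc(Br)c3)ccc12` differs from compound 3 by methyl in place of hydrogen on a saturated chain carbon bound to an oxygen on an aromatic ring. Among the measured compounds shown here, the only single-change step measured, a 2.3-fold lower number from compound 1 to compound 2 (0.36 log units; beyond the scatter), concerns a halogen and does not bear directly on this change. Compounds 1 and 2 carry ethoxy while compound 3 carries methoxy, but the gap between compound 2 and compound 3 also contains a halogen change, so the ethoxy effect cannot be separated from it. Compound 4 is therefore expected to show a 3.5-fold higher number from compound 3 to compound 4 (0.54 log units; beyond the scatter), a modest weakening with wide uncertainty. The estimate for compound 4 in this assay is 20 nM, within 5 nM to 80 nM.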

Compound 4, half-maximal inhibitory concentration: 126 nM
Estimate against measurement, compound 4: 6.3-fold (0.80 log units) below, outside the stated range (above it).
By their numbers in this assay, from the lowest: compound 3; then compounds 2 and 4 (each within the scatter of the next); then compound 1.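

Within the bromo compounds in this assay, methoxy to ethoxy brings a large loss (a 22-fold higher number from compound 3 to compound 4 (1.34 log units; beyond the scatter)), showing that this position tolerates even methyl in place of hydrogen poorly. Among the ethoxy compounds, changing the halogen does far less: bromo in place of chloro stays within the scatter (a 1.1-fold higher number from compound 2 to compound 4 (0.04 log units; within the scatter)), and bromo in place of fluoro gives a modest step (a 2.1-fold lower number from compound 1 to compound 4 (0.32 log units; beyond the scatter)). Nothing available explains the size of the methoxy to ethoxy step.

As far as these compounds go, whether that step is the same with chloro or fluoro remains open. So does the outcome of a longer chain such as propoxy, or of an amine on that chain.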